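The source may report more compounds than this note shows. Statements on the series, on what has been measured and on what is new or still open speak of the compounds shown alone.

Working notes on the series. Compound 1 `O=C(NOCc1ccccc1F)c1cn(-c2ccccc2)nc1-c1ccccc1` and compound 2 `O=C(NOCc1ccccc1Cl)c1cn(-c2ccccc2)nc1-c1ccccc1` share one core; compound 3 `COc1ccc(-c2nn(-c3ccccc3)cc2C(=O)NOCc2ccccc2F)cc1` and the unmeasured compound 4 `COc1ccc(-c2nn(-c3ccccc3)cc2C(=O)NOCc2ccccc2Cl)cc1` share another. The two cores differ by methoxy in place of hydrogen on an aromatic carbon. In a functional assay on MCF7 cells (Homo sapiens) for antiproliferative activity, read by MTT assay, with a stated time of 48 h, in the presence of a further agent that is not named here (on this read-out higher numbers stand for weaker inhibition of growth and lower numbers for stronger inhibition of growth), compound 1 gives 16100 nM, and compound 3 gives 6000 nM, the step being a 2.7-fold lower number from compound 1 to compound 3 (0.43 log units; beyond the scatter). In this assay compound 2 gives 7410 nM; the values of compound 2 and compound 3 lie within the usual scatter of each other, so no order between the two is drawn.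

The change from compound 1 to compound 2 is chloro in place of fluoro on an aromatic carbon, and it produces a 2.2-fold lower number from compound 1 to compound 2 (0.34 log units; beyond the scatter). The change from compound 3 to compound 4 is chloro in place of fluoro on an aromatic carbon. Going by the values given here, the surroundings of the place read the same, word for word, for both pairs, so this is the same change made on the other core; among the compounds here it occurs twice in all, with only one instance measured.

In this assay compound 4 is expected at about 3000 nM, with a likely range from 1300 nM to 7000 nM. For compound 4 the estimated step of a 2.0-fold lower number from compound 3 to compound 4 (0.30 log units; within the scatter) is taken slightly smaller than the measured one, because a 2.2-fold lower number from compound 1 to compound 2 (0.34 log units; beyond the scatter) rests on a single pair and is only modestly beyond the scatter.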

Compound 4, concentration for 50% growth inhibition: 3730 nM
Compound 4: the middle estimate sits 1.2-fold (0.09 log units) below what was measured; the measured number falls inside the stated range.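

In this assay, chloro in place of fluoro on an aromatic carbon gives a 1.6-fold lower number from compound 3 to compound 4 (0.21 log units; within the scatter), and set beside the earlier instance on the other core, the two steps do not differ beyond what repeated measurement allows: the same change on two cores in this assay, a 2.2-fold lower number (0.34 log units; beyond the scatter) from compound 1 to compound 2 and a 1.6-fold lower number (0.21 log units; within the scatter) from compound 3 to compound 4, 1.4-fold (0.13 log units) apart, within the scatter of two such steps Methoxy in place of hydrogen on an aromatic carbon gives a 2.0-fold lower number from compound 2 to compound 4 (0.30 log units; within the scatter), and this step also stands close to its earlier instance: the same change on two cores in this assay, a 2.7-fold lower number (0.43 log units; beyond the scatter) from compound 1 to compound 3 and a 2.0-fold lower number (0.30 log units; within the scatter) from compound 2 to compound 4, 1.4-fold (0.13 log units) apart, within the scatter of two such steps The four compounds therefore show both changes carrying from one core to the other with no detectable difference in size, but each new step taken alone lies within the scatter, so the data do not establish a real effect of either change on its second core, and one set of four compounds in a single assay does not show that this holds for other cores in the series.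

The compounds shown leave open whether a bromo or a nitrile in place of the chloro would follow the same course on both cores. They also leave open whether an amine, a carboxylic acid or a longer chain in place of the methoxy would carry across in the same way.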